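Compound 1 to compound 4: the ester group leaves

This account rests on a few compounds, and the source may have more. Where it says the series, first, only, none or still open, it means among the compounds named here.

For the measured compounds named here, in a functional assay on K562 cells (Homo sapiens) for antiproliferative activity, read by MTT assay, with a stated time of 6 days (a lower number here means a stronger inhibitor, a higher number a weaker inhibitor), compound 1 (`COc1ccc(/C=C/C(=O)OC[C@@H](OCc2ccccc2)[C@H]2OC(=O)C=C[C@H]2OCc2ccccc2)cc1`) gives 430 nM, the lowest of the three numbers so far. Compound 2 (`O=C1C=C[C@@H](OCc2ccccc2)[C@@H]([C@@H](COC(=O)/C=C/c2ccc([N+](=O)[O-])cc2)OCc2ccccc2)O1`) gives 1270 nM, and compound 3 (`CC(=O)O[C@@H]1C=CC(=O)O[C@@H]1[C@@H](COC(=O)/C=C/c1ccc([N+](=O)[O-])cc1)OC(C)=O`) gives 2340 nM. Compound 4 (`O=C1C=C[C@@H](OCc2ccccc2)[C@@H]([C@@H](CO)OCc2ccccc2)O1`) differs from compound 1 by hydrogen in place of (2-(4-methoxyphenyl)ethenyl)carbonyl on an oxygen on a saturated carbon. Going by the values given here, one measured step bears on this change: a 3.0-fold higher number from compound 1 to compound 2 (0.47 log units; beyond the scatter), modest but beyond the scatter, with nitro in place of methoxy on an aromatic carbon. Among the compounds with values here, that step alters the leaving group only in part, and no measured compound lacks the group. A higher number of similar or somewhat larger size is therefore expected in this assay. The expected step is a 3.5-fold higher number from compound 1 to compound 4 (0.54 log units; beyond the scatter). Compound 4 is estimated at 1500 nM, with an expected range of 350 nM to 6500 nM.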

Compound 4, half-maximal inhibitory concentration: 1420 nM
The estimate for compound 4 lay 1.1-fold (0.02 log units) above the measured number; the measured number falls inside the stated range.
By their numbers in this assay, from the lowest: compound 1; then compounds 2, 4 and 3 (each within the scatter of the next).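

In this assay, stripping the whole (2-(4-methoxyphenyl)ethenyl)carbonyl group from this oxygen gives a 3.3-fold higher number from compound 1 to compound 4 (0.52 log units; beyond the scatter), a modest change that is beyond the scatter. The group therefore adds to the activity of compound 1 but is not required for it: compound 4, with hydrogen at this oxygen, still gives 1420 nM. No available measurement bears on why the number rises. Still open is which part of the leaving group accounts for the step; a benzoyl or phenylpropanoyl group on this oxygen would separate the aromatic ring from the double bond.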